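Replacing 4-carboxyphenyl with (phenylsulfonyl)amino

This account rests on a few compounds, and the source may have more. Where it says the series, first, only, none or still open, it means among the compounds named here.

In an ADME assay on WI-38 cells (Homo sapiens) for cytotoxicity, read by sulforhodamine B assay, with a stated time of 24 h (on this read-out higher numbers stand for weaker inhibition and lower numbers for stronger inhibition), compound 2 `O=C1Nc2ccc(S(=O)(=O)N3CCOCC3)cc2/C1=N/c1ccc(C(=O)O)cc1` gives 313000 nM. Compound 1 `Cc1ccc(S(=O)(=O)N/N=C2\C(=O)Nc3ccc(S(=O)(=O)N4CCOCC4)cc32)cc1` gives 261000 nM, and these two numbers lie within the usual scatter of each other, so neither can be ranked above the other. Compound 3 `O=C1Nc2ccc(S(=O)(=O)N3CCOCC3)cc2/C1=N/NS(=O)(=O)c1ccccc1` differs from compound 2 by having (phenylsulfonyl)amino in place of 4-carboxyphenyl on a double-bonded nitrogen. Going by the values given here, no measured pair shows what this change does. With compound 1 at 261000 nM, no step beyond the scatter is expected in this assay, in either direction. The expected step is a 1.2-fold lower number from compound 2 to compound 3 (0.06 log units; within the scatter). Compound 3 is estimated at 270000 nM, with an expected range of 130000 nM to 520000 nM.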

Compound 3, half-maximal inhibitory concentration: 302000 nM
The estimate for compound 3 lay 1.1-fold (0.05 log units) below the measured number, within the range that was stated.
By their numbers in this assay, from the lowest: compounds 1, 3 and 2 (each within the scatter of the next).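

In this assay, (phenylsulfonyl)amino in place of 4-carboxyphenyl on a double-bonded nitrogen gives a 1.0-fold lower number from compound 2 to compound 3 (0.02 log units; within the scatter) and so leaves the number unmoved, although the two groups differ in their atoms. Hydrogen in place of methyl on an aromatic carbon gives a 1.2-fold higher number from compound 1 to compound 3 (0.06 log units; within the scatter) and so also makes no readable difference. Nothing measured here offers an explanation for either result.

Still open, from the compounds shown here alone, is whether a simple amine on the double-bonded nitrogen, or a chlorine in place of that methyl, would shift the number beyond the scatter.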